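Notes on the urea series: amine swap at the chain terminus

A few compounds are considered here, and "the series" means these few. Any claim that something is new, unique, unknown or untested is made for them only; others in the source may bear on it.

Among the compounds with values here, the three measured members share one core and differ only in the aryl group on the urea. Compound 1 `N#Cc1cccc([C@]23CCC(N(CCN4CC[C@@H](O)C4)C(=O)Nc4ccccc4)CC2C3)c1` gives 132 nM in a functional assay for antagonist activity at melanin-concentrating hormone receptor 1 (Homo sapiens); a lower number here means a stronger inhibitor, a higher number a weaker inhibitor. Compound 2 `N#Cc1cccc([C@]23CCC(N(CCN4CC[C@@H](O)C4)C(=O)Nc4cccc(Br)c4)CC2C3)c1` gives 34 nM, and the step of a 3.9-fold lower number from compound 1 to compound 2 (0.59 log units; beyond the scatter). Compound 3 `N#Cc1cccc(NC(=O)N(CCN2CC[C@@H](O)C2)C2CC[C@]3(c4cccc(C#N)c4)CC3C2)c1` gives 92 nM; it stands second highest of the three numbers, with a 1.4-fold lower number from compound 1 to compound 3 (0.16 log units; within the scatter) and a 2.7-fold higher number from compound 2 to compound 3 (0.43 log units; beyond the scatter).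

Compound 4 `CC(C)N(CCN(C(=O)Nc1cccc(C#N)c1)C1CC[C@]2(c3cccc(C#N)c3)CC2C1)C(C)C` keeps the aryl group of compound 3 and changes the chain instead: diisopropylamino in place of 3-hydroxypyrrolidin-1-yl on a saturated chain carbon, two bonds along the chain from an amide-type nitrogen. Within the data shown here, none of the three measured steps touches this part of the molecule; all of them vary the aromatic substituent, so no measured step bears directly on the swap. The expectation therefore rests only on the fact that the rest of compound 4 is identical to compound 3, and the estimated step of a 1.1-fold higher number from compound 3 to compound 4 (0.04 log units; within the scatter) is set close to no change, with a wide range in either direction. Compound 4 is estimated at 100 nM, expected to lie between 30 nM and 350 nM.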

Compound 4, inhibition constant: 7.6 nM
For compound 4 the middle estimate is 13-fold (1.12 log units) above the measured one, outside the stated range (below it).
By their numbers in this assay, from the lowest: compound 4; then compound 2; then compounds 3 and 1 (each within the scatter of the next).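

The chain terminus is a sensitive position: in this assay, diisopropylamino in place of 3-hydroxypyrrolidin-1-yl gives a 12-fold lower number from compound 3 to compound 4 (1.08 log units; beyond the scatter), a larger step than any of the aryl changes on the urea, the biggest of which is a 3.9-fold lower number from compound 1 to compound 2 (0.59 log units; beyond the scatter). With the aryl group of compound 3, neither the ring, the hydroxyl group nor the defined stereocentre of 3-hydroxypyrrolidin-1-yl is needed for a low number, and compound 4 has the lowest of the four values. The swap changes all of these at once, along with the hydrogen-bond donor and acceptor counts of the group, and nothing shown separates their contributions or explains the step.

As far as these compounds go, it remains open whether the gain carries over to the bromo-substituted aryl group of compound 2. Also open, from the compounds shown here alone, is how a piperidine, a morpholine or a dimethylamino group would behave at this chain terminus.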